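This account rests on a few compounds, and the source may have more. Where it says the series, first, only, none or still open, it means among the compounds named here.

Working notes on the series. In a functional assay on MCF7 cells (Homo sapiens) for antiproliferative activity, read by MTT assay, with a stated time of 48 h (a higher number here means a weaker inhibitor, a lower number a stronger inhibitor), compound 1 (`O=[N+]([O-])c1ccc(-c2nn(-c3ccccc3)cc2C(Nc2nc3ccccc3s2)c2c(O)ccc3ccccc23)cc1`) gives 14700 nM and compound 2 (`COc1ccc2nc(NC(c3cn(-c4ccccc4)nc3-c3ccc(Cl)cc3)c3c(O)ccc4ccccc34)sc2c1`) gives 23700 nM as its reading, so compound 2 stands level with compound 1, the two values lying within the scatter of each other. Compound 3 (`COc1ccc2nc(NC(c3cn(-c4ccccc4)nc3-c3ccc([N+](=O)[O-])cc3)c3c(O)ccc4ccccc34)sc2c1`) follows from compound 2 by one change, nitro in place of chloro on an aromatic carbon, para to a large group, which turns 4-chlorophenyl into 4-nitrophenyl (nitro in place of chloro on an aromatic carbon). For the measured compounds named here, no measured pair isolates this change, so the expectation in this assay rests only on these two values. No step beyond the scatter is expected, and no direction is favoured. The estimated 1.2-fold lower number from compound 2 to compound 3 (0.10 log units; within the scatter) is expected to stay within the scatter. Compound 3 is estimated at 19000 nM with an expected range of 8000 nM to 45000 nM in this measurement.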

Compound 3, half-maximal inhibitory concentration: 13300 nM
Estimate against measurement, compound 3: 1.4-fold (0.15 log units) above; the measured number falls inside the stated range.
By their numbers in this assay, from the lowest: compounds 3, 1 and 2 (each within the scatter of the next).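

In this assay, nitro in place of chloro on an aromatic carbon, para to a large group, gives a 1.8-fold lower number from compound 2 to compound 3 (0.25 log units; within the scatter), so this position does not separate 4-nitrophenyl from 4-chlorophenyl in this read-out. With 4-nitrophenyl held fixed, methoxy in place of hydrogen on an aromatic carbon gives a 1.1-fold lower number from compound 1 to compound 3 (0.04 log units; within the scatter), so this second site also shows no step beyond the scatter, and the three compounds stand level. No measurement bears on either step.

Only chloro and nitro are shown at the first position, so it remains open whether an amine, a carboxylic acid or a longer chain there would give a step beyond the scatter. At the second site, only hydrogen and methoxy are shown, which leaves groups such as ethoxy or an amine open as well.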